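A few compounds are considered here, and "the series" means these few. Any claim that something is new, unique, unknown or untested is made for them only; others in the source may bear on it.

Compound 1 `Nc1nn2c(O)cc(-c3cc([N+](=O)[O-])c(Cl)cc3Cl)nc2c1[N+](=O)[O-]` in a functional assay on K562 cells (Homo sapiens) for inhibition (a higher number here means a weaker inhibitor of growth, a lower number a stronger inhibitor of growth), reaches only the limit > 50 ug/mL. Compound 2 `Nc1nn2c(O)cc(CCl)nc2c1[N+](=O)[O-]` in this assay likewise gives only the limit > 50 ug/mL. Compound 3 `NNCc1cc(O)n2nc(N)c([N+](=O)[O-])c2n1` in this assay gives 26.5 ug/mL.

For the measured compounds named here, compound 3 thus holds the only number in this set; the two other results are limits, as summed up by the limit of > 50 ug/mL in this assay, at which 2 of the 3 values shown sit. Going by the values given here, the one measured step in the set is an at least 1.8-fold lower number from compound 2 to compound 3 (0.27 log units; that floor lies within the scatter), a floor that lies within the usual scatter, so it gives no reliable size. Compound 4 `Nc1nn2c(O)cc(CNNCCO)nc2c1[N+](=O)[O-]` differs from compound 3 by 2-hydroxyethyl in place of hydrogen on an amine nitrogen. Among the compounds with values here, the only measured step that bears on this change is the one already named, and it sets no size beyond the scatter; no other measured pair speaks to a substituent on this amine nitrogen. Compound 4 is therefore expected to show no step beyond the scatter, a 1.1-fold lower number from compound 3 to compound 4 (0.03 log units; within the scatter). The growth-inhibiting concentration of compound 4 in this assay is estimated at 25 ug/mL, with a range from 10 ug/mL to 60 ug/mL.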

Compound 4, concentration for 50% growth inhibition: > 50 ug/mL
Compound 4 was reported as a limit; the forecaster's own chance of this, stated with the estimate: 30%; middle value at least 2.0-fold (0.30 log units) from the limit.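

In this assay, putting 2-hydroxyethyl in place of hydrogen on an amine nitrogen gives an at least 1.8-fold higher number from compound 3 to compound 4 (0.27 log units; that floor lies within the scatter), so this substitution shows no sign of a gain, while the true size of the step stays unread. The step from chloro to ((2-hydroxyethyl)amino)amino on the saturated chain carbon cannot be read, as both of its ends are limits. The unsubstituted aminoamino chain of compound 3 thus remains the only one in the set with a number rather than a limit: the limit of > 50 ug/mL in this assay, at which 3 of the 4 values shown sit.

Going by these compounds, only 2-hydroxyethyl stands on this amine nitrogen, so it remains open whether a methyl group or a longer chain ending in a carboxylic acid would give a number in this assay. On these data alone, the true values behind the limits of compound 2 and compound 4 also stay open.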